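Fluoro on the distal phenyl of compound 2

The source may hold more compounds than are shown below. What is called first, only, known or untested is meant among the compounds shown, and "the series" means these compounds.

Two compounds have a record in a functional assay on Jurkat cells (Homo sapiens) for activation, with a stated time of 24 h; a higher number here means that more compound is needed for the effect, a lower number that less compound is needed. Compound 1 `N#Cc1ccccc1-c1ccc(NCc2ccccc2O)cc1` is reported in this assay as "not active" (no number reported), which is not a number, so nothing can be set against it. Compound 2 `Oc1ccccc1CNc1ccc(-c2ccccc2)nc1` gives 840 nM in this assay, the only numerical entry in the series, and so compound 2 is the single point of reference. Compound 3 `Oc1ccccc1CNc1ccc(-c2ccc(F)cc2)nc1` is not yet measured. The change from compound 2 to compound 3 is fluoro in place of hydrogen on an aromatic carbon. The fluoro enters on an aromatic carbon of a six-membered aromatic ring of carbon only, para to a large group; read one bond further out, phenyl becomes 4-fluorophenyl. Going by the values given here, no measured pair differs in this way, so there is no step to lean on. With one heavy atom entering and no donors or acceptors, the step expected here is a 1.2-fold lower number from compound 2 to compound 3 (0.08 log units; within the scatter), a shift not beyond the usual scatter in either direction. Compound 3 is therefore expected to give about 700 nM in this assay, within 300 nM to 2000 nM.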

Compound 3, half-maximal effective concentration: 2590 nM
Beside the measured number, compound 3's estimate is 3.7-fold (0.57 log units) below it; measured number outside the range, above it.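

In this assay, going by these compounds alone, this is the first step that can be read at a single place: a 3.1-fold higher number from compound 2 to compound 3 (0.49 log units; beyond the scatter). It shows that this position is not indifferent to substitution, since fluoro in place of hydrogen on this aromatic carbon, para to a large group, means that more compound is needed for the effect, although the step is modest. Nothing shown here accounts for the shift, so the result stands as an observation without an explanation.

As far as these compounds go, whether the higher number belongs to fluoro in particular or to any group entering at this carbon remains open, and a chloro, a methoxy or an amine at the same place would help to separate those two readings. It is also open whether this single step carries over to other carbons of the same ring, since the phenyl to 4-fluorophenyl change is the only one of its kind among the compounds shown and no second pair yet tests it.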